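A few compounds are considered here, and "the series" means these few. Any claim that something is new, unique, unknown or untested is made for them only; others in the source may bear on it.

Working notes on the series. The read-out throughout is a functional assay on Maver1 cells (Homo sapiens) for inhibition, read by luminescence and CellTiter-Glo, with a stated time of 72 h; a higher number here means a weaker inhibitor, a lower number a stronger inhibitor. Compound 1, `C/C=C/C(=O)Nc1cccc(Cn2nc(-c3ccc(Oc4ccccc4)cc3)cc2C(=O)O)c1`, gives 31600 nM in this assay. Compound 2, `O=C(CCl)Nc1ccc(Cn2nc(-c3ccc(Oc4ccccc4)cc3)cc2C(=O)O)cc1`, gives 1200 nM in this assay. On these two numbers compound 2 stands lowest; the nearest number is that of compound 1, which lies far higher, well beyond the scatter. Among the compounds with values here, no single-point step can be drawn between compound 1 and compound 2, since the two differ both in the amide on the phenyl ring and in where that amide sits, so the two values are stated side by side and nothing more is read from them.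

Compound 3, `O=C(CCl)Nc1cccc(Cn2nc(-c3ccc(Oc4ccccc4)cc3)cc2C(=O)O)c1`, is the next compound to be measured. It differs from compound 2 in one place: 3-(((chloromethyl)carbonyl)amino)phenyl in place of 4-(((chloromethyl)carbonyl)amino)phenyl on a saturated chain carbon bound to an aromatic nitrogen. The pair has the same atoms, joined differently.

Within the data shown here, no measured step of this kind exists, so the size of the change in this assay for compound 3 is open. Compound 3 carries its amide where compound 1 does, but the amide itself is a different one, and in this assay compound 1 gives 31600 nM, so that number cannot settle the matter. For compound 3 a moderate step toward a higher number, from compound 2 to compound 3, a 2.5-fold higher number from compound 2 to compound 3 (0.40 log units; beyond the scatter), is expected rather than a large one. Compound 3 is estimated at 3000 nM, with a range from 600 nM to 15000 nM.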

Compound 3, half-maximal inhibitory concentration: 4700 nM
The estimate for compound 3 lay 1.6-fold (0.19 log units) below the measured number; the range from low to high includes it.
By their numbers in this assay, from the lowest: compound 2; then compound 3; then compound 1.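

In this assay, 3-(((chloromethyl)carbonyl)amino)phenyl in place of 4-(((chloromethyl)carbonyl)amino)phenyl on a saturated chain carbon bound to an aromatic nitrogen gives a 3.9-fold higher number from compound 2 to compound 3 (0.59 log units; beyond the scatter), so with the amide group unchanged, the place of attachment on the phenyl ring alone moves the number beyond the scatter. With that attachment held fixed, chloromethyl in place of prop-1-en-1-yl on a carbonyl carbon gives a 6.7-fold lower number from compound 1 to compound 3 (0.83 log units; beyond the scatter), so the group on the carbonyl carbon also matters in its own right, and the gap between compound 1 and compound 2, which could not be read as a single step before, now resolves into two steps that each lie beyond the scatter. The data shown offer no measurement that accounts for either step.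

Going by these compounds, it remains open whether the change of attachment has a similar effect when prop-1-en-1-yl sits on the carbonyl carbon, since this pair rests on chloromethyl alone. On these data alone, it is also open where a plain methyl on the carbonyl carbon, or a free amine on the phenyl ring in place of the whole amide, would fall in this assay.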